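The source may hold more compounds than are shown below. What is called first, only, known or untested is meant among the compounds shown, and "the series" means these compounds.

Measured compounds:
Compound 1 `O=C(CCc1ccc(C(F)(F)F)cc1)Nc1ccc2nc(N3CCC3)ccc2c1` gives 4 nM in an assay on isolated protein for displacement of a labelled ligand from melanin-concentrating hormone receptor 1 (Homo sapiens); on this read-out higher numbers stand for weaker inhibition and lower numbers for stronger inhibition.
Compound 2 `CN(c1ccc2cc(NC(=O)CCc3ccc(C(F)(F)F)cc3)ccc2n1)C1CCCC1` gives 2 nM in this assay.

Compound 2 and compound 1 are indistinguishable within the scatter of this assay, since the step of a 2.0-fold lower number from compound 1 to compound 2 (0.30 log units; within the scatter) is no larger than repeat measurements of the same compound would be. Compound 3 `CN(C)c1ccc2cc(NC(=O)CCc3ccc(C(F)(F)F)cc3)ccc2n1` is an untested neighbour of compound 2. The change is methyl in place of cyclopentyl on a nitrogen on an aromatic ring: a ring of carbon atoms leaves and the smallest possible carbon group takes its place on the same nitrogen. Among the measured compounds shown here, only one measured step bears on this position, the one from compound 1 to compound 2, and it stayed within the scatter when a small ring gave way to a larger substituent. Shrinking the substituent again is therefore expected to move the number little, with perhaps a slight rise, giving an expected step of a 2.5-fold higher number from compound 2 to compound 3 (0.40 log units; beyond the scatter). Compound 3 is expected to give about 5 nM, with a range from 2 nM to 15 nM.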

Compound 3, half-maximal inhibitory concentration: 13 nM
For compound 3 the middle estimate is 2.6-fold (0.41 log units) below the measured one, and the stated range covers the measured number.
By their numbers in this assay, from the lowest: compounds 2 and 1 (each within the scatter of the next); then compound 3.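

In this assay, among the compounds shown here, the group on this nitrogen does matter: replacing cyclopentyl with methyl gives a 6.5-fold higher number from compound 2 to compound 3 (0.81 log units; beyond the scatter), whereas the only earlier step at this position stayed within the scatter. Changing the azetidin-1-yl group to dimethylamino also gives a clear rise, a 3.3-fold higher number from compound 1 to compound 3 (0.51 log units; beyond the scatter), so among these three compounds the dimethylamino group, the only one with no ring, gives the highest number, and compound 1 and compound 2 cannot be told apart. No supporting measurements are available to explain this difference.

As far as these compounds go, it remains open whether the ring itself counts or simply the number of carbons attached through this nitrogen. Diethylamino, an open-chain group with more carbons, and pyrrolidin-1-yl, a ring of intermediate size, would help separate these two readings.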